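A few compounds are considered here, and "the series" means these few. Any claim that something is new, unique, unknown or untested is made for them only; others in the source may bear on it.

Measured so far:
- compound 1 `COc1cc([C@@H]2C[C@]2(CO)C(=O)Nc2ccccc2Cl)cc(OC)c1OC`: 16900 nM
- compound 2 `CCOC(=O)[C@@]1(C(=O)Nc2ccccc2Cl)C[C@@H]1c1cc(OC)c(OC)c(OC)c1`: 49400 nM

In a functional assay on K562 cells (Homo sapiens) for cytotoxicity, read by MTT assay, with a stated time of 48 h (on this read-out higher numbers stand for weaker inhibition and lower numbers for stronger inhibition), compound 2 gives 49400 nM, the higher of the two numbers, and its gap to compound 1 lies beyond the scatter. Compound 3 `COc1cc([C@H]2C[C@@]2(CO)C(=O)Nc2ccccc2Cl)cc(OC)c1OC` is not yet measured. It departs from compound 2 by one change: hydroxymethyl in place of ethoxycarbonyl on a saturated ring carbon. Going by the values given here, the only measured compound with hydroxymethyl is compound 1 at 16900 nM, so a move to a lower number is expected. The expected step in this assay is a 2.5-fold lower number from compound 2 to compound 3 (0.39 log units; beyond the scatter). For compound 3 the estimate is 20000 nM, with an expected range of 7000 nM to 60000 nM.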

Compound 3, half-maximal inhibitory concentration: > 100000 nM
Compound 3: only a limit was reported; the forecaster's own chance of this, stated with the estimate: 15%; at least 5.0-fold (0.69 log units) between middle value and limit.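

In this assay compound 3 reads > 100000 nM, which is a limit and not a number. Hydroxymethyl in place of ethoxycarbonyl on this saturated ring carbon gives an at least 2.0-fold higher number from compound 2 to compound 3 (0.30 log units; that floor lies within the scatter), so this change alone is not resolved from the scatter. Hydroxymethyl does not by itself set the number, and an at least 5.9-fold higher number from compound 1 to compound 3 (0.77 log units; beyond the scatter) points to configuration as a factor at this position, on this evidence: the fact that compounds 1 and 3 differ only in the configuration as drawn.

The compounds shown do not separate the contributions of the two inverted stereocentres. They also leave open how a carboxylic acid or an aminomethyl group on this saturated ring carbon would read, in either configuration.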